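Swapping the amide aryl group on a flavonol antiproliferative scaffold

The source may hold more compounds than are shown below. What is called first, only, known or untested is meant among the compounds shown, and "the series" means these compounds.

Of the compounds shown here, three sharing one core have been measured in a functional assay on MDA-MB-231 cells (Homo sapiens) for antiproliferative activity, read by CCK-8 assay, with a stated time of 72 h; a higher number here means a weaker inhibitor, a lower number a stronger inhibitor. Compound 1 `O=C(Nc1cccc(-c2oc3cc(-c4ccc(F)cc4)ccc3c(=O)c2O)c1)c1ccc(Cl)cc1` gives 12800 nM, compound 2 `COc1ccccc1C(=O)Nc1cccc(-c2oc3cc(-c4ccc(F)cc4)ccc3c(=O)c2O)c1` gives 5110 nM, and compound 3 `Cc1cccc(C(=O)Nc2cccc(-c3oc4cc(-c5ccc(F)cc5)ccc4c(=O)c3O)c2)c1` gives 2840 nM. Compound 2 thus holds the second highest number of the three: the step of a 2.5-fold lower number from compound 1 to compound 2 (0.40 log units; beyond the scatter) lies beyond the scatter, while the step of a 1.8-fold lower number from compound 2 to compound 3 (0.26 log units; within the scatter) does not, and a 4.5-fold lower number from compound 1 to compound 3 (0.65 log units; beyond the scatter) is the largest movement seen.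

Compound 4 `Cc1cc(C(=O)Nc2cccc(-c3oc4cc(-c5ccc(F)cc5)ccc4c(=O)c3O)c2)ccc1F` differs from compound 2 by 4-fluoro-3-methylphenyl in place of 2-methoxyphenyl on a carbonyl carbon. The step from compound 2 to compound 3 bears most directly on it, since compound 3 already carries a 3-methylphenyl on the carbonyl carbon, and that step stayed within the scatter. Compound 4 is therefore expected to land close to compound 3, so the step of a 2.0-fold lower number from compound 2 to compound 4 (0.31 log units; beyond the scatter) is expected to be small and within the scatter. Compound 4 is estimated at 2500 nM in this assay, with a range from 900 nM to 7000 nM.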

Compound 4, half-maximal inhibitory concentration: 7440 nM
The estimate for compound 4 lay 3.0-fold (0.47 log units) below the measured number, and the stated range ends below it.
By their numbers in this assay, from the lowest: compounds 3, 2, 4 and 1 (each within the scatter of the next, the first and the last beyond it).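

In this assay, the smallest change in the set, fluoro in place of hydrogen on an aromatic carbon, produces a step beyond the scatter (a 2.6-fold higher number from compound 3 to compound 4 (0.42 log units; beyond the scatter)), so the number for the 3-methylphenyl amide of compound 3 did not carry over to the 4-fluoro-3-methylphenyl amide of compound 4. The other two new steps (a 1.5-fold higher number from compound 2 to compound 4 (0.16 log units; within the scatter) and a 1.7-fold lower number from compound 1 to compound 4 (0.24 log units; within the scatter)) both stay within the scatter, so compound 4 cannot be ranked against compound 2 or compound 1. No measurement shown here explains why the added fluoro is accompanied by this higher number.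

As far as these compounds go, it remains open whether a 4-fluorophenyl group without the methyl would give a similar number in this assay. Also open, from the compounds shown here alone, is how an aryl group carrying an amine or a carboxylic acid would behave on this carbonyl carbon.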